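Swapping an Aryl Ring for a Piperidinylmethyl Amide

The source may report more compounds than this note shows. Statements on the series, on what has been measured and on what is new or still open speak of the compounds shown alone.

Measured so far:
compound 1, `Fc1cc(-c2nc(N3CCN(c4ncccc4C(F)(F)F)CC3)[nH]c2-c2ccc(C(F)(F)F)cc2)cc(F)c1F`, 7 nM
compound 2, `C[C@@H]1CN(c2ncc(CO)cc2Cl)CCN1c1nc(-c2cc(F)c(F)c(F)c2)c(-c2ccc(C(F)(F)F)cc2)[nH]1`, 1 nM

In a functional assay on CHO cells for antagonist activity at transient receptor potential cation channel subfamily V member 1 (Rattus norvegicus), read by calcium flux (a higher number here means a weaker inhibitor, a lower number a stronger inhibitor), compound 1 gives 7 nM, the higher of the two numbers recorded. Compound 2 gives 1 nM in this assay, a lower number than that of compound 1 by a margin beyond the usual scatter. For the measured compounds named here, compound 2 differs from compound 1 in more than one place, so the two values show only that compound 2 is the stronger inhibitor of the pair.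

Compound 3, `O=C(NCC1CCCCN1)c1nc(N2CCN(c3ncccc3C(F)(F)F)CC2)[nH]c1-c1ccc(C(F)(F)F)cc1`, has not yet been tested. It keeps the shared core of compound 1 and its 4-(trifluoromethyl)phenyl group; the change is ((piperidin-2-yl)methyl)carbamoyl in place of 3,4,5-trifluorophenyl on an aromatic carbon. An aromatic ring is thereby exchanged for an amide carrying a saturated ring with hydrogen-bond donors and acceptors. Going by the values given here, no measured step shows what this exchange does, and both measured compounds carry the 3,4,5-trifluorophenyl group, so nothing here tells how much of the activity rests on it. The expectation is for a weakening: the step from compound 1 to compound 3 is expected to be a 14-fold higher number from compound 1 to compound 3 (1.15 log units; beyond the scatter), a loss beyond the scatter. Compound 3 is therefore estimated at 100 nM, within a range from 15 nM to 1000 nM.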

Compound 3, half-maximal inhibitory concentration: 2950 nM
Beside the measured number, compound 3's estimate is 30-fold (1.47 log units) below it, outside the stated range (above it).
By their numbers in this assay, from the lowest: compound 2; then compound 1; then compound 3.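

In this assay, for the compounds shown here, putting ((piperidin-2-yl)methyl)carbamoyl in place of 3,4,5-trifluorophenyl on this aromatic carbon of the five-membered ring gives a 420-fold higher number from compound 1 to compound 3 (2.62 log units; beyond the scatter), a large step and the only measured change at this position. It shows that the activity of compound 1 depends strongly on what stands here, since the shared core and the 4-(trifluoromethyl)phenyl group, both kept in compound 3, do not on their own preserve a low number. No measurement given here accounts for the size of this loss, so it cannot be assigned to the departure of the aromatic ring or to the arrival of the amide or the saturated ring.

All of these parts change together in the single step, so the compounds shown leave open which of them carries the loss. A plain phenyl ring, a simple methyl amide or a piperidine ring joined without the carbonyl at this position would each separate one part from the others, and would show whether any group other than a fluorinated phenyl ring can keep the number low.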